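Carbamate in place of ester chain on the shared core

This account rests on a few compounds, and the source may have more. Where it says the series, first, only, none or still open, it means among the compounds named here.

Measured compounds:
compound 1 `CCOC(=O)CCCN(c1ccccc1)[C@H]1c2cc(C#N)ccc2OC(C)(C)[C@@H]1O`, > 30000 nM
compound 2 `CCOC(=O)CN(c1nc2ccccc2o1)[C@H]1c2cc(C#N)ccc2OC(C)(C)[C@@H]1O`, > 30000 nM

In a functional assay (aorta) with Rattus norvegicus as the target (on this read-out lower numbers stand for stronger inhibition and higher numbers for weaker inhibition), compound 1 gives only a limit, > 30000 nM. Compound 2 likewise gives only a limit, > 30000 nM. Both values sit at the same limit, so nothing separates the two compounds on the numbers shown (the limit of > 30000 nM in this assay, at which 2 of the 2 values shown sit). Compound 3 `CCOC(=O)NN(c1ccccc1)[C@H]1c2cc(C#N)ccc2OC(C)(C)[C@@H]1O` has (ethoxycarbonyl)amino in place of 3-(ethoxycarbonyl)propyl on a nitrogen on an aromatic ring. Within the data shown here, with no step between measured compounds to draw on, the step from compound 1 to compound 3 is expected to stay within the scatter, a number no higher from compound 1 to compound 3 (the limit leaves the size open), and compound 3 is estimated at 30000 nM, between 5000 nM and 100000 nM.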

Compound 3, half-maximal inhibitory concentration: 2200 nM
Estimate against measurement, compound 3: 14-fold (1.13 log units) above; measured number outside the range, below it.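

The substituent on this nitrogen can bring the shared core off the limit: (ethoxycarbonyl)amino in place of 3-(ethoxycarbonyl)propyl gives an at least 13-fold lower number from compound 1 to compound 3 (1.13 log units; beyond the scatter) in this assay. Among these compounds, the earlier compounds showed only limits, so this is the first sign that the read-out responds to a change at this position. The size of the step is only a bound because compound 1 stands at a limit: the limit of > 30000 nM in this assay, at which 2 of the 3 values shown sit.

The change swaps a carbon chain for a shorter group that brings a nitrogen and a hydrogen-bond donor, and the compounds shown do not separate these features. From the compounds shown here alone, how an acetylamino group or a plain amine would read at this position remains open.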